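A few compounds are considered here, and "the series" means these few. Any claim that something is new, unique, unknown or untested is made for them only; others in the source may bear on it.

Compound 3 `COC(=O)/C(=C/c1ccccc1)CN1C(=O)[C@@H](OC)[C@H]1c1ccccc1` is one of four closely related compounds in this series; in an ADME assay on cells (Epithelial cell, Homo sapiens) for antiproliferative activity, read by MTT assay, with a stated time of 48 h (a higher number here means a weaker inhibitor, a lower number a stronger inhibitor), compound 3 gave "not toxic" (no number reported), so it stands without a number among the measured compounds. Its two numbered companions both sit weak: compound 1 `COC(=O)/C(=C/c1ccccc1)CN1C(=O)[C@@H](OC)[C@H]1c1ccc(Cl)cc1` gave 37900 nM in this assay, and compound 2 `COC(=O)/C(=C/c1ccccc1)CN1C(=O)[C@@H](OC)[C@H]1c1cccc(C(F)(F)F)c1` gave 71800 nM, with a 1.9-fold higher number from compound 1 to compound 2 (0.28 log units; within the scatter). Compound 4 `COC(=O)/C(=C/c1ccccc1)CN1C(=O)[C@@H](OC)[C@H]1c1ccc(OC)cc1` differs from compound 3 in one place: methoxy in place of hydrogen on an aromatic carbon. Going by the values given here, no measured step in this set swaps a hydrogen for a methoxy group, so the only guide is that the step from compound 1 to compound 2, an exchange of aryl substituents on the same saturated ring carbon, stayed inside the scatter, and that compound 3 itself gave no number at all. On that basis compound 4 is expected to remain a weak inhibitor, with a real chance that this assay again reports no number. The estimate for compound 4 in this assay is 60000 nM, with a range from 20000 nM to 150000 nM.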

Compound 4, half-maximal inhibitory concentration: "not toxic" (no number reported)
For compound 4 the study gives words and no number; no gap can be computed for the estimate.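

Compound 3 and compound 4 both came back from this assay as "not toxic" with no number, so no step can be read between them. Nothing shown here bears on this result. The compounds shown leave open how far compound 3 and compound 4 actually lie from compound 1 in this assay.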